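A few compounds are considered here, and "the series" means these few. Any claim that something is new, unique, unknown or untested is made for them only; others in the source may bear on it.

Compound 1 `CCOC(=O)C1(C(=O)Nc2ccccc2)CC1c1cc(OC)c(OC)c(OC)c1`: > 100000 nM; > 100000 nM (2 entries) (a limit)
Compound 2 `CCOC(=O)[C@]1(C(=O)Nc2ccccc2)C[C@H]1c1cc(OC)c(OC)c(OC)c1`: > 100000 nM (a limit)
Compound 3 `CCOC(=O)[C@]1(C(=O)Nc2ccccc2)C[C@@H]1c1cc(OC)c(OC)c(OC)c1`: > 100000 nM (a limit)

All three compounds were tested in a functional assay on K562 cells (Homo sapiens) for cytotoxicity, read by MTT assay, with a stated time of 48 h (a lower number here means a stronger inhibitor, a higher number a weaker inhibitor), and none gave a true number. Compound 2 sits at > 100000 nM, which is a limit of the assay and not a measured potency. Among the compounds with values here, the only measured step is a step that the two limits leave unreadable from compound 2 to compound 3, and it changes configuration alone (the fact that compounds 2 and 3 differ only in the configuration as drawn). It therefore gives no size to carry forward.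

Compound 4 `CCOC(=O)[C@]1(C(=O)Nc2ccccc2Cl)C[C@H]1c1cc(OC)c(OC)c(OC)c1` keeps the configuration of compound 2 and changes one place: chloro in place of hydrogen on an aromatic carbon. This is chloro in place of hydrogen on an aromatic carbon, turning phenyl into 2-chlorophenyl, ortho to a large group. Within the data shown here, no measured step here tests such a change. With compound 2 at > 100000 nM as the starting limit, the working expectation in this assay is no readable shift in either direction. The expected step is a number no higher from compound 2 to compound 4 (the limit leaves the size open). Compound 4 is expected at about 100000 nM, with an estimated range from 30000 nM to 300000 nM, and most likely it will again return only a limit.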

Compound 4, half-maximal inhibitory concentration: 20700 nM
Estimate against measurement, compound 4: 4.8-fold (0.68 log units) above; measured number below the stated range.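

In this assay compound 4 is the only one of the four to give a true number, and chloro in place of hydrogen on an aromatic carbon, ortho to a large group, brings an at least 4.8-fold lower number from compound 2 to compound 4 (0.68 log units; beyond the scatter) in this series. Within the data shown here, this place on the phenyl therefore responds to a change, which the earlier compounds, all held at a limit, could not show. The step gives only a minimum size because it starts from a limit: the limit of > 100000 nM in this assay, at which 2 of the 4 values shown sit.

Nothing shown says why chloro has this effect, or whether fluoro, bromo, methyl or methoxy at the same place would do the same. Also open, on these data alone, is whether the 2-chlorophenyl group would give a readable number on compound 3, with its other configuration.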